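Adding a Second Methyl to the Thiosemicarbazide Coumarin

The source may report more compounds than this note shows. Statements on the series, on what has been measured and on what is new or still open speak of the compounds shown alone.

Of the compounds shown here, two sharing a coumarin-type core have been measured so far. Compound 1 `Cc1c(C)c2ccc(OCC(=O)NN)cc2oc1=O` carries a hydrazide tail; compound 2 `Cc1cc(=O)oc2cc(OCC(=O)NNC(=S)Nc3ccc(Cl)cc3)ccc12` carries a thiosemicarbazide tail ending in a chlorophenyl group. In an assay for inhibition of Amine oxidase [flavin-containing] A (Bos taurus), read by fluorescence, with a stated time of 30 min (a higher number here means a weaker inhibitor, a lower number a stronger inhibitor), compound 2 gives 0.00701 nM. This is the larger of the two figures recorded, but compound 1 gives 0.00501 nM, and the gap between the two lies within the usual scatter of such measurements, so no real difference between them can be claimed.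

Compound 3 `Cc1c(C)c2ccc(OCC(=O)NNC(=S)Nc3ccc(Cl)cc3)cc2oc1=O` has not yet been measured. It differs from compound 2 by a single change: methyl in place of hydrogen on an aromatic carbon. For the measured compounds named here, nothing among the measured pairs isolates this change, so there is no step on record to lean on. Given that compound 1 and compound 2 differ at two places yet stay within the scatter of each other, the account expects the step of a 1.2-fold lower number from compound 2 to compound 3 (0.07 log units; within the scatter) to be small, with no direction beyond the scatter. Compound 3 is therefore estimated to give 0.006 nM in this assay, within a range from 0.002 nM to 0.02 nM.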

Compound 3, inhibition constant: 0.00651 nM
Compound 3: the middle estimate sits 1.1-fold (0.04 log units) below what was measured; measured number inside the range.
By their numbers in this assay, from the lowest: compounds 1, 3 and 2 (each within the scatter of the next).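

Methyl in place of hydrogen on an aromatic carbon, two atoms from the ring oxygen and ortho to a methyl group, can now be read directly for the first time: in this assay it amounts to a 1.1-fold lower number from compound 2 to compound 3 (0.03 log units; within the scatter), and that step lies within the scatter. With the thiosemicarbazide tail ending in a chlorophenyl group held the same, this position therefore takes a methyl with no difference that this assay can resolve, so compound 2 and compound 3 stand level on these figures. Nothing shown here gives a reason for this result.

As far as these compounds go, whether the same position would read alike with an ethyl group, a methoxy group or an amine remains open, as does whether the methyl would read the same with a hydrazide tail like that of compound 1. From the compounds shown here alone, the chlorophenyl end is also shared by compound 2 and compound 3, so what a plain phenyl or a carboxylic acid at that end would do remains unknown.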